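Trimethoxyphenyl pyrazole chalcones: swapping the aminophenyl ketone

The compounds below may be only part of what the source reports. "The series", "measured", "known", "first", "only" and "open" are said of these compounds alone.

Compound 1 `COc1cc(-c2cc(/C=C/C(=O)c3ccc(N)cc3)[nH]n2)cc(OC)c1OC` carries a 4-aminophenyl group on its ketone and was tested in a functional assay on OVCAR-3 cells (Homo sapiens) for inhibition, read by sulforhodamine B assay, with a stated time of 48 h (on this read-out higher numbers stand for weaker inhibition of growth and lower numbers for stronger inhibition of growth), where compound 1 gives 1570 nM. Of the two numbers available it is the higher one, but its nearest neighbour, compound 2 `COc1ccc(-c2cc(/C=C/C(=O)c3ccc(OC)c(OC)c3)[nH]n2)cc1`, gives 1190 nM in this assay, and the two values lie within the usual scatter of each other, so no order between them can be claimed. Compound 3 `COc1cc(-c2cc(/C=C/C(=O)c3ccc(Cl)c(Cl)c3)[nH]n2)cc(OC)c1OC` has not yet been measured. It differs from compound 1 in one place: 3,4-dichlorophenyl in place of 4-aminophenyl on a carbonyl carbon. Within the data shown here, no measured pair shows what this change does, so the expectation rests on the closeness of compound 1 and compound 2 alone. Compound 3 is expected to change by a 1.6-fold lower number from compound 1 to compound 3 (0.20 log units; within the scatter), a step that may well stay within the scatter. The value of compound 3 in this assay is estimated at 1000 nM, somewhere between 300 nM and 3500 nM.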

Compound 3, concentration for 50% growth inhibition: 6990 nM
Beside the measured number, compound 3's estimate is 7.0-fold (0.84 log units) below it; the whole stated range lies below it.
By their numbers in this assay, from the lowest: compounds 2 and 1 (each within the scatter of the next); then compound 3.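

On the core of compound 1, the group on the carbonyl carbon is not indifferent in this assay: 3,4-dichlorophenyl in place of 4-aminophenyl gives a 4.5-fold higher number from compound 1 to compound 3 (0.65 log units; beyond the scatter), a modest step but one beyond the scatter, and so weaker inhibition of growth. This is the first single change shown at this position, and it shows that an aromatic ring of carbon only on the carbonyl carbon does not by itself hold the value. No measurement accompanies this step that could account for it.

Two things change at once here, so the compounds shown leave open whether the step follows the loss of the amine or the arrival of the chlorines. An unsubstituted phenyl or a 4-chlorophenyl on the same carbonyl carbon would bear on that question.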